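The source may report more compounds than this note shows. Statements on the series, on what has been measured and on what is new or still open speak of the compounds shown alone.

Measured in a functional assay on K562 cells (Homo sapiens) for cytotoxicity, read by trypan blue exclusion, with a stated time of 96 h; a higher number here means a weaker inhibitor, a lower number a stronger inhibitor:
compound 1 `COc1ccc(/C=C/S(=O)(=O)Nc2ccc(F)cc2)cc1` gives 10000 nM
compound 2 `COc1cc(OC)c(/C=C/S(=O)(=O)Nc2ccc(OC)c(F)c2)c(OC)c1` gives 75 nM
compound 3 `COc1ccc(NS(=O)(=O)/C=C/c2cc(OC)c(OC)c(OC)c2)cc1N` gives 15000 nM

Compound 2 has the lowest number of the three, and compound 1 and compound 3 both lie above it, beyond the scatter. Compound 4 `COC(=O)C(Nc1cc(NS(=O)(=O)/C=C/c2c(OC)cc(OC)cc2OC)ccc1OC)c1ccccc1` differs from compound 2 by one change, in place of one fluorine atom on an aromatic carbon: a group of 12 heavy atoms (9 carbon, 1 nitrogen, 2 oxygen; one six-membered aromatic ring of carbon only) in place of one fluorine atom, on an aromatic carbon. Among the measured compounds shown here, no measured pair isolates this change. Compound 3, with an amino group at that place and differently placed methoxy groups, gives 15000 nM in this assay, so a weaker result is expected. Compound 4 keeps the methoxy groups of compound 2, so the expected loss is smaller, beyond the scatter: a 4.0-fold higher number from compound 2 to compound 4 (0.60 log units; beyond the scatter) upward. For compound 4 the estimated value is 300 nM, with an expected range of 60 nM to 2500 nM.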

Compound 4, half-maximal inhibitory concentration: 2500 nM
Compound 4: the middle estimate sits 8.3-fold (0.92 log units) below what was measured, within the range that was stated.
By their numbers in this assay, from the lowest: compound 2; then compound 4; then compounds 1 and 3 (each within the scatter of the next).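

In this assay, replacing the fluoro group, ortho to a methoxy group, with the group of 12 heavy atoms gives a 33-fold higher number from compound 2 to compound 4 (1.52 log units; beyond the scatter), a large step beyond the scatter. Among the compounds shown here, this is the first single-change reading at this place, and it shows that the large group weakens the result without abolishing it: compound 4 still reads 2500 nM. Nothing available explains the size of this step.

Still open, on these data alone, is which part of the large group matters: the aromatic ring, the ester or the nitrogen link. A carboxylic acid in place of the ester, or a single chlorine atom in place of the fluoro group, would help separate these.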